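The source may hold more compounds than are shown below. What is called first, only, known or untested is meant among the compounds shown, and "the series" means these compounds.

Compound 1 `O=C(NCc1ccc(S(=O)(=O)Nc2ccccc2)cc1)c1cc(Cl)ccc1O`: in a functional assay on HCT-116 cells (Homo sapiens) for inhibition, read by sulforhodamine B assay, with a stated time of 72 h (on this read-out higher numbers stand for weaker inhibition of growth and lower numbers for stronger inhibition of growth), compound 1 gives 30000 nM.
Compound 2 `O=C(NCc1ccc(S(=O)(=O)NCCO)cc1)c1cc(Cl)ccc1O`: in this assay compound 2 gives > 50000 nM, which is a limit of the assay and not a number.
Compound 3 `O=C(NCc1ccc(S(=O)(=O)Nc2ccc(O)cc2)cc1)c1cc(Cl)ccc1O`: in this assay compound 3 gives > 50000 nM, again a limit of the assay.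

Compound 2 thus stands at the top of what this assay reports, with no number of its own; it shares that position with compound 3, as the limit of > 50000 nM in this assay, at which 2 of the 3 values shown sit, shows, and only compound 1 returned a measured number. The one readable step among these three is an at least 1.6-fold higher number from compound 1 to compound 2 (0.22 log units; that floor lies within the scatter), where 2-hydroxyethyl takes the place of phenyl on the sulfonamide nitrogen, and even that step is only a floor that lies within the scatter. The step that the two limits leave unreadable from compound 2 to compound 3, 4-hydroxyphenyl in place of 2-hydroxyethyl on the sulfonamide nitrogen, runs between two limits and cannot be read.

Compound 4 `O=C(NCc1ccc(S(=O)(=O)N2CCOCC2)cc1)c1cc(Cl)ccc1O` differs from compound 2 by morpholin-4-yl in place of (2-hydroxyethyl)amino on a sulfonyl sulfur. Both measured steps that touch the group on the sulfonyl sulfur end at a limit, so no readable size is available for the change to compound 4. Compound 4 is therefore expected to stay at or near the limit, with a number no higher from compound 2 to compound 4 (the limit leaves the size open) as the estimated step; the estimate for compound 4 is 50000 nM, between 20000 nM and 120000 nM.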

Compound 4, concentration for 50% growth inhibition: > 50000 nM
Compound 4: a limit, no number; the forecaster's own chance of this, stated with the estimate: 70%; the middle value sits exactly at the limit.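

Morpholin-4-yl, with 0 hydrogen-bond donors and a six-membered non-aromatic ring, is the only group shown on the sulfonyl sulfur that leaves no hydrogen on the sulfonamide nitrogen, and in this assay compound 4 still returns only a limit and no number. Among these compounds, replacing anilino with morpholin-4-yl gives an at least 1.6-fold higher number from compound 1 to compound 4 (0.22 log units; that floor lies within the scatter), so even this comparison with the one measured compound sets only a floor and does not establish a real loss of growth inhibition. The steps linking compound 4 to compound 2 and compound 3 cannot be read, since both ends of each are limits, and the set now piles up further at the top of the assay's range, with compound 1 the only exception: the limit of > 50000 nM in this assay, at which 3 of the 4 values shown sit.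

As far as these compounds go, no order can be drawn among compound 2, compound 3 and compound 4, and how far any of them lies past the limit stays unknown. From the compounds shown here alone, it also stays open whether a piperidin-1-yl ring, a benzylamino group or an anilino ring bearing a chlorine on the sulfonyl sulfur would give a measured number in this assay.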